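Carbamate-bearing indole sulfonamides: swapping the amide on the ring nitrogen

The source may hold more compounds than are shown below. What is called first, only, known or untested is meant among the compounds shown, and "the series" means these compounds.

Measured compounds:
compound 1 `COc1cc(C(=O)NS(=O)(=O)c2ccccc2C)ccc1Cc1cn(C(F)F)c2ccc(NC(=O)OC3CCCC3)cc12`, 1 nM
compound 2 `COc1cc(C(=O)NS(=O)(=O)c2ccccc2C)ccc1Cc1c[nH]c2ccc(NC(=O)OC3CCCC3)cc12`, 1 nM
compound 3 `CCN(CC)C(=O)n1cc(Cc2ccc(C(=O)NS(=O)(=O)c3ccccc3C)cc2OC)c2cc(NC(=O)OC3CCCC3)ccc21`, 0.5 nM

All three values come from an assay on isolated protein for binding affinity to cysteinyl leukotriene receptor 1 (Cavia porcellus); on this read-out lower numbers stand for stronger inhibition and higher numbers for weaker inhibition. Compound 3 holds the lowest number, but its gaps to compound 1 and compound 2, a 2.0-fold lower number from compound 1 to compound 3 (0.30 log units; within the scatter) and a 2.0-fold lower number from compound 2 to compound 3 (0.30 log units; within the scatter), are both within the scatter, as is no change at the digits printed from compound 1 to compound 2 (within the scatter). Compound 4 `COc1cc(C(=O)NS(=O)(=O)c2ccccc2C)ccc1Cc1cn(C(=O)NCCN(C)C)c2ccc(NC(=O)OC3CCCC3)cc12` follows from compound 3 by (2-(dimethylamino)ethyl)amino in place of diethylamino on a carbonyl carbon. Among the measured compounds shown here, no measured step alters this part of the molecule; the three steps that bear on it only show that the group on the aromatic nitrogen, whether hydrogen, difluoromethyl or diethylcarbamoyl, leaves this assay essentially unchanged. Compound 4 is therefore expected at 0.7 nM, between 0.3 nM and 2 nM. The expected step of a 1.4-fold higher number from compound 3 to compound 4 (0.15 log units; within the scatter) lies within the scatter.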

Compound 4, half-maximal inhibitory concentration: 0.5 nM
For compound 4 the middle estimate is 1.4-fold (0.15 log units) above the measured one; low and high end bracket the measured number.
By their numbers in this assay, from the lowest: compounds 3, 4, 1 and 2 (each within the scatter of the next).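

On the carbonyl carbon whose other neighbour is the aromatic nitrogen, the exchange of diethylamino for (2-(dimethylamino)ethyl)amino gives no change at the digits printed from compound 3 to compound 4 (within the scatter) in this assay and so shows that the amine part of this carbamoyl group can change without moving the number beyond the scatter. The comparisons a 2.0-fold lower number from compound 2 to compound 4 (0.30 log units; within the scatter) and a 2.0-fold lower number from compound 1 to compound 4 (0.30 log units; within the scatter) add (2-(dimethylamino)ethyl)carbamoyl to the groups on the aromatic nitrogen that stay within the scatter of hydrogen and difluoromethyl. No measurement shown here explains this result. As far as these compounds go, whether a carboxylic acid or a longer chain in place of the dimethylamino end would also stay within the scatter remains open.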